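Hydrazide in place of the acylsulfonamide on the shared core

A few compounds are considered here, and "the series" means these few. Any claim that something is new, unique, unknown or untested is made for them only; others in the source may bear on it.

Compound 3 `CS(=O)(=O)NC(=O)c1ccc(-c2cc(-c3ccc(C#N)cc3)nc(-c3ccco3)c2)cc1` gives 10000 nM in an assay on cells for binding affinity to Myc proto-oncogene protein (Homo sapiens) (a higher number here means a weaker inhibitor, a lower number a stronger inhibitor), the highest of the three numbers in hand. Compound 1 `N#Cc1ccc(-c2cc(-c3ccccc3)cc(-c3ccco3)n2)cc1` gives 5000 nM and compound 2 `N#Cc1ccc(-c2cc(-c3ccc(-c4nnn[nH]4)cc3)cc(-c3ccco3)n2)cc1` gives 2000 nM; the step of a 2.0-fold higher number from compound 1 to compound 3 (0.30 log units; within the scatter) is within the scatter, while a 5.0-fold higher number from compound 2 to compound 3 (0.70 log units; beyond the scatter) is a modest worsening. Compound 4 `N#Cc1ccc(-c2cc(-c3ccc(C(=O)NN)cc3)cc(-c3ccco3)n2)cc1` differs from compound 3 by amino in place of methylsulfonyl on an amide-type nitrogen. Going by the values given here, no measured step touches the amide-type nitrogen, so only the steps to compound 1 and compound 2 bear on it, and they show that this carbonyl-bearing substituent sits at the weak end of the set. The estimate for compound 4 is 5000 nM, with a range of 2000 nM to 15000 nM, a step of a 2.0-fold lower number from compound 3 to compound 4 (0.30 log units; within the scatter) that is expected but uncertain.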

Compound 4, half-maximal inhibitory concentration in the Myc proto-oncogene protein assay: > 100000 nM
Compound 4: a limit, no number; the forecaster's own chance of this, stated with the estimate: 20%; middle value at least 20-fold (1.30 log units) away from the limit.
By their numbers in the Myc proto-oncogene protein assay, from the lowest: compound 2; then compounds 1 and 3 (each within the scatter of the next). At a limit, above all of these: compound 4.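

Compound 4 gives > 100000 nM in the Myc proto-oncogene protein assay, a limit and not a number. The aminocarbamoyl group is therefore far less tolerated here than hydrogen, 1H-tetrazol-5-yl or (methylsulfonyl)carbamoyl: an at least 20-fold higher number from compound 1 to compound 4 (1.30 log units; beyond the scatter), an at least 50-fold higher number from compound 2 to compound 4 (1.69 log units; beyond the scatter), and an at least 10-fold higher number from compound 3 to compound 4 (1.00 log units; beyond the scatter). In a physicochemical assay for solubility, at pH 6 (on this read-out lower numbers stand for lower solubility and higher numbers for higher solubility), compound 3 gives 32000 nM and compound 4 gives 500000 nM. In the physicochemical assay, the same change runs the other way, so the loss does not track lower solubility: the measured solubility of compound 3, 32000 nM, and of compound 4, 500000 nM, a 16-fold higher number (1.19 log units; beyond the scatter)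

As far as these compounds go, how far compound 4 lies past its limit remains open. Also open, from the compounds shown here alone, is whether the loss follows the amino on the amide-type nitrogen itself; a methyl on that nitrogen, or a carboxylic acid in place of the whole aminocarbamoyl, would bear on this.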